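The compounds below may be only part of what the source reports. "The series", "measured", "known", "first", "only" and "open" are said of these compounds alone.

Series notes. Compound 1 `COc1cc(-c2cc(COCc3cn(Cc4cc(-c5ccccc5)cnc4Cl)nn3)on2)cc(OC)c1OC` and compound 2 `COc1cc(-c2cc(COCc3cn(Cc4cc(-c5ccc(C)cc5)cnc4Cl)nn3)on2)cc(OC)c1OC` share one core; compound 3 `COc1cc(COCc2cn(Cc3cc(-c4ccc(C)cc4)cnc3Cl)nn2)cc(OC)c1OC` carries a different core, and the difference between the two cores is not broken down here. In a functional assay on MCF7 cells (Homo sapiens) for cytotoxicity, read by MTT assay, with a stated time of 48 h (a lower number here means a stronger inhibitor, a higher number a weaker inhibitor), compound 2 gives 58400 nM and compound 1 gives 68500 nM. The change from compound 2 to compound 1 is hydrogen in place of methyl on an aromatic carbon, and it made a step of a 1.2-fold higher number from compound 2 to compound 1 (0.07 log units; within the scatter). In this assay compound 3 gives 146000 nM, the highest number of the three measured, beyond the scatter from both compound 1 and compound 2. Compound 4 `COc1cc(COCc2cn(Cc3cc(-c4ccccc4)cnc3Cl)nn2)cc(OC)c1OC` is the counterpart of compound 3 with the same change: hydrogen in place of methyl on an aromatic carbon. The place is described in the same words as for the change from compound 2 to compound 1, so the change is treated as the same. For the measured compounds named here, with only one measured instance, the expectation rests on the step of a 1.2-fold higher number from compound 2 to compound 1 (0.07 log units; within the scatter) applied to compound 3, which gives an expected step of a 1.2-fold higher number from compound 3 to compound 4 (0.07 log units; within the scatter). Compound 4 is therefore expected to give 170000 nM in this assay, estimated to fall between 85000 nM and 340000 nM. Whether the weak numbers in this part of the series stay clear of the assay's upper limit remains to be seen.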

Compound 4, half-maximal inhibitory concentration: 86700 nM
Beside the measured number, compound 4's estimate is 2.0-fold (0.29 log units) above it, and the stated range covers the measured number.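

In this assay, the change from 4-methylphenyl to phenyl gives a 1.7-fold lower number from compound 3 to compound 4 (0.23 log units; within the scatter), so on this core, as on the core of compound 1, the step stays within the scatter. Set side by side, the two steps show no measurable dependence on the core: the same change on two cores in this assay, a 1.2-fold higher number (0.07 log units; within the scatter) from compound 2 to compound 1 and a 1.7-fold lower number (0.23 log units; within the scatter) from compound 3 to compound 4, 2.0-fold (0.30 log units) apart, within the scatter of two such steps. For the compounds shown here, this supports carrying the change between these two cores as a change with no resolved effect on the number, but it rests on only two pairs and does not show that the cores respond identically, since a core dependence smaller than the scatter would go unseen.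

The compounds shown carry only hydrogen or methyl at this place on the aromatic ring, so it stays open whether an amine, a carboxylic acid or a longer chain there would give a step beyond the scatter, and whether such a step would carry from one core to the other. The difference between the two cores also remains unresolved, as it is not broken down into single changes.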